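A few compounds are considered here, and "the series" means these few. Any claim that something is new, unique, unknown or untested is made for them only; others in the source may bear on it.

In a functional assay on KM12 cells (Homo sapiens) for antiproliferative activity (a lower number here means a stronger inhibitor of growth, a higher number a weaker inhibitor of growth), compound 1 `COc1ccc(-c2nc3cc(F)ccc3s2)cc1` gives 24600 nM, compound 2 `COc1ccc(-c2nc3cc(F)ccc3s2)cc1C` gives 18600 nM, and compound 3 `COc1ccc(-c2nc3cc(F)ccc3s2)cc1Cl` gives 7050 nM. Compound 3 thus has the lowest number of the three, and its gaps to both others lie beyond the scatter. Compound 4 `COc1ccc(-c2nc3cc(F)ccc3s2)cc1I` differs from it in one place: iodo in place of chloro on an aromatic carbon. This is iodo in place of chloro on an aromatic carbon, ortho to a methoxy group.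

Three measured steps at that same carbon bear on this change. Methyl in place of hydrogen gave a 1.3-fold lower number from compound 1 to compound 2 (0.12 log units; within the scatter), chloro in place of hydrogen gave a 3.5-fold lower number from compound 1 to compound 3 (0.54 log units; beyond the scatter), and chloro in place of methyl gave a 2.6-fold lower number from compound 2 to compound 3 (0.42 log units; beyond the scatter). None of them involves iodo, so they offer only a weak guide to direction and an upper sense of size. On that basis, a small move toward a lower number is expected in this assay, an estimated 1.4-fold lower number from compound 3 to compound 4 (0.15 log units; within the scatter). For compound 4 the estimated value is 5000 nM, with an expected range of 1500 nM to 15000 nM.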

Compound 4, concentration for 50% growth inhibition: 6900 nM
Compound 4: the middle estimate sits 1.4-fold (0.14 log units) below what was measured; low and high end bracket the measured number.
By their numbers in this assay, from the lowest: compounds 4 and 3 (each within the scatter of the next); then compounds 2 and 1 (each within the scatter of the next).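

Iodo in place of chloro gives a 1.0-fold lower number from compound 3 to compound 4 (0.01 log units; within the scatter) in this assay and so leaves the two groups indistinguishable at this carbon. Iodo also matches the shift seen earlier for chloro, with a 3.6-fold lower number from compound 1 to compound 4 (0.55 log units; beyond the scatter) for iodo in place of hydrogen and a 2.7-fold lower number from compound 2 to compound 4 (0.43 log units; beyond the scatter) for iodo in place of methyl as the comparison with the two earlier groups, so compound 3 and compound 4 now stand together apart from compound 1 and compound 2. On these data alone, whether bromo, a nitrile or an amine at this carbon would fall with chloro and iodo or with hydrogen and methyl remains open. Nothing shown here speaks to what lies behind the close match of chloro and iodo.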